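Series notes: compound 2 and the planned compound 3

The source may hold more compounds than are shown below. What is called first, only, known or untested is meant among the compounds shown, and "the series" means these compounds.

Measured so far:
compound 1, `Cc1ccccc1Nc1nc(Nc2ccc(N3CCCCC3)cc2)ncc1Cl`: > 100000 nM
compound 2, `Cc1ccc(CNc2nc(Nc3ccc(N4CCN(C)CC4)cn3)ncc2Cl)cc1`: 38100 nM

Going by the values given here, in a functional assay on MCF7 cells (Homo sapiens) for inhibition, read by CCK-8 assay, with a stated time of 48 h (a lower number here means a stronger inhibitor of growth, a higher number a weaker inhibitor of growth), compound 2 gives 38100 nM, the only number recorded. The figure for compound 1 is a limit of the assay, not a number, as noted in the limit of > 100000 nM in this assay, at which 1 of the 2 values shown sits. Compound 2 therefore stands alone without a measured neighbour to rank against.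

Compound 3, `CC(C)c1ccc(Nc2nc(Nc3ccc(N4CCN(C)CC4)cn3)ncc2Cl)cc1`, differs from compound 2 by 4-isopropylphenyl in place of 4-methylbenzyl on a nitrogen on an aromatic ring. Among the compounds with values here, no step between measured compounds is available to calibrate this change, so only a modest gain in this assay is expected, with the expected step being a 1.9-fold lower number from compound 2 to compound 3 (0.28 log units; within the scatter). Compound 3 is estimated at 20000 nM, within a range of 5000 nM to 80000 nM.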

Compound 3, concentration for 50% growth inhibition: 1880 nM
For compound 3 the middle estimate is 11-fold (1.03 log units) above the measured one; the measured number lies below the stated range.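

In this assay, 4-isopropylphenyl in place of 4-methylbenzyl on a nitrogen on an aromatic ring gives a 20-fold lower number from compound 2 to compound 3 (1.31 log units; beyond the scatter). Going by these compounds alone, this is the first readable step, and it shows that the group on this nitrogen can move the growth-inhibition number well beyond the scatter. Nothing shown gives a reason for the size of this step.

Still open, from the compounds shown here alone, is whether the step follows the change from benzyl to phenyl or the change from methyl to isopropyl. 4-Methylphenyl or 4-isopropylbenzyl on the same nitrogen would separate the two.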